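From Methoxycarbonyl to Propyl on the Amide Carbonyl

The source may hold more compounds than are shown below. What is called first, only, known or untested is meant among the compounds shown, and "the series" means these compounds.

The three measured compounds share the core seen in compound 1 `COc1cc(/C=C/C(=O)c2cccc(NC(=O)c3ccccc3)c2)ccc1O`, while compound 2 `COc1cc(/C=C/C(=O)c2cccc(NC(=O)c3cc(Cl)cc(Cl)c3)c2)ccc1O` and compound 3 `COC(=O)C(=O)Nc1cccc(C(=O)/C=C/c2ccc(O)c(OC)c2)c1` vary the group on the amide carbonyl. In a functional assay on SiHa cells (Homo sapiens) for inhibition (on this read-out lower numbers stand for stronger inhibition and higher numbers for weaker inhibition), compound 1 gives 4.57 ug/mL, compound 2 gives 17.7 ug/mL and compound 3 gives 7.71 ug/mL. Compound 3 thus stands second highest of the three numbers, nearest to compound 1 and furthest from compound 2: the step of a 1.7-fold higher number from compound 1 to compound 3 (0.23 log units; within the scatter) lies within the scatter, whereas a 2.3-fold lower number from compound 2 to compound 3 (0.36 log units; beyond the scatter) and a 3.9-fold higher number from compound 1 to compound 2 (0.59 log units; beyond the scatter) are beyond it.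

Compound 4 `CCCC(=O)Nc1cccc(C(=O)/C=C/c2ccc(O)c(OC)c2)c1` continues the series at the same position: propyl in place of methoxycarbonyl on a carbonyl carbon. Among the compounds with values here, all three measured steps concern this carbonyl carbon, yet none of them places a propyl there, so no step matches the change directly. The measured numbers span only a modest range, and the two departures from compound 1 read a 3.9-fold higher number from compound 1 to compound 2 (0.59 log units; beyond the scatter) and a 1.7-fold higher number from compound 1 to compound 3 (0.23 log units; within the scatter). On that basis the step of a 1.2-fold lower number from compound 3 to compound 4 (0.07 log units; within the scatter) is expected to stay small, at most modest in either direction. Compound 4 is therefore estimated at 6.5 ug/mL in this assay, with an expected range from 2.5 ug/mL to 16 ug/mL.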

Compound 4, half-maximal inhibitory concentration: 3.94 ug/mL
Estimate against measurement, compound 4: 1.6-fold (0.22 log units) above; the measured number falls inside the stated range.
By their numbers in this assay, from the lowest: compounds 4, 1 and 3 (each within the scatter of the next); then compound 2.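

Propyl on the carbonyl carbon gives the first group in the series with no ring and no hydrogen-bond acceptors, yet in this assay it does not separate from the groups it was compared with: the steps to it from phenyl (a 1.2-fold lower number from compound 1 to compound 4 (0.06 log units; within the scatter)) and from methoxycarbonyl (a 2.0-fold lower number from compound 3 to compound 4 (0.29 log units; within the scatter)) both stay within the scatter. Among the four compounds, only the 3,5-dichlorophenyl group stands apart, and the step to propyl (a 4.5-fold lower number from compound 2 to compound 4 (0.65 log units; beyond the scatter)) lies beyond the scatter, so neither a ring nor the hydrogen-bond acceptors of methoxycarbonyl are needed at this place for a number like that of compound 1. Nothing shown here offers an explanation for these steps.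

The compounds leave open whether the distance of compound 2 from the others belongs to its two chlorines or to the substituted ring as a whole, which a phenyl bearing a single chlorine would help to separate. They also leave open how far this flat picture extends, for instance to a longer chain such as hexyl, or to an amine or a carboxylic acid at the end of a chain on this carbonyl carbon.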